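Swapping the amide substituent of compound 1 for a chloropyridinyl

This account rests on a few compounds, and the source may have more. Where it says the series, first, only, none or still open, it means among the compounds named here.

Of the compounds shown here, three sharing one core have been measured in a functional assay on HepG2 cells (Homo sapiens) for inhibition, read by MTT assay, with a stated time of 72 h; a lower number here means a stronger inhibitor, a higher number a weaker inhibitor. Compound 1 `Cc1noc(C)c1-c1cnc(N)c(Oc2ccc(C(=O)NC3CC3)cc2)n1` carries a cyclopropyl group on the amide-type nitrogen, and in this assay compound 1 gives 43200 nM, the highest number of the three. Compound 2 `Cc1noc(C)c1-c1cnc(N)c(Oc2ccc(C(=O)Nc3cccc(Cl)c3)cc2)n1` gives 7300 nM, and compound 3 `Cc1noc(C)c1-c1cnc(N)c(Oc2ccc(C(=O)Nc3cccc(Cl)n3)cc2)n1` gives 35700 nM.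

The new compound, compound 4 `Cc1noc(C)c1-c1cnc(N)c(Oc2ccc(C(=O)Nc3cc(Cl)ccn3)cc2)n1`, differs from compound 1 in one place: 4-chloropyridin-2-yl in place of cyclopropyl on an amide-type nitrogen.

For the measured compounds named here, two measured steps bear on this change, both replacing the same cyclopropyl on the same amide-type nitrogen with a chlorinated aromatic ring. The step of a 5.9-fold lower number from compound 1 to compound 2 (0.77 log units; beyond the scatter) shows a clear gain, whereas the step of a 1.2-fold lower number from compound 1 to compound 3 (0.08 log units; within the scatter) shows none beyond the scatter. Compound 4 resembles compound 3 most closely, being a pyridin-2-yl that differs only in where the chlorine sits, so a small gain at most is expected. Compound 4 is therefore estimated at 22000 nM, with a range of 7000 nM to 50000 nM, which means an expected step of a 2.0-fold lower number from compound 1 to compound 4 (0.29 log units; within the scatter).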

Compound 4, half-maximal inhibitory concentration: > 100000 nM
Compound 4: no number, only a limit (the forecaster's own chance of this, stated with the estimate: 5%); middle value at least 4.5-fold (0.65 log units) away from the limit.
By their numbers in this assay, from the lowest: compound 2; then compounds 3 and 1 (each within the scatter of the next). At a limit, above all of these: compound 4.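

Compound 4 gives no number, only a limit of the assay: the limit of > 100000 nM in this assay, at which 1 of the 4 values shown sits.

Position on the pyridin-2-yl matters at this amide-type nitrogen: 4-chloropyridin-2-yl in place of 6-chloropyridin-2-yl gives an at least 2.8-fold higher number from compound 3 to compound 4 (0.44 log units; beyond the scatter), so two rings with the same atoms do not read alike. The change from cyclopropyl to 4-chloropyridin-2-yl gives an at least 2.3-fold higher number from compound 1 to compound 4 (0.36 log units; beyond the scatter), the only step shown from compound 1 that raises the number, and 4-chloropyridin-2-yl in place of 3-chlorophenyl gives an at least 13-fold higher number from compound 2 to compound 4 (1.13 log units; beyond the scatter).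

The compounds shown leave open how much of this pattern follows the chlorine and how much the ring nitrogen, a question that an unsubstituted pyridin-2-yl or a plain phenyl on the same nitrogen would address. The limit also leaves the full size of these steps open.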